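This account rests on a few compounds, and the source may have more. Where it says the series, first, only, none or still open, it means among the compounds named here.

Compound 1 `CCCCNc1nc(N)nc2c1CN(S(C)(=O)=O)CC2`: 9.9 uM
Compound 2 `CCCCNc1nc(N)nc2c1CCN(S(C)(=O)=O)C2`: 0.8 uM

Both numbers come from an assay on HEK293 cells for agonist activity at Toll-like receptor 8 (Homo sapiens), read by a luciferase reporter, with a stated time of 6 h; a higher number here means that more compound is needed for the effect, a lower number that less compound is needed. Of the two, compound 1 stands highest, and the gap to compound 2 lies well beyond the scatter. Compound 3 `CCCCNc1nc(N)nc2c1CN(C(=O)c1csc(N)n1)CC2` is still unmeasured in this assay. Compared with compound 1 it carries (2-amino-1,3-thiazol-4-yl)carbonyl in place of methylsulfonyl on an amine nitrogen in a ring. Within the data shown here, no measured pair here shows how such a change acts, so the direction is uncertain. A modest step toward a lower number is expected, of about a 2.5-fold lower number from compound 1 to compound 3 (0.39 log units; beyond the scatter), with wide bounds. Compound 3 is therefore estimated to give 4 uM in this assay, expected to fall between 0.8 uM and 20 uM.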

Compound 3, minimum effective concentration: 6.9 uM
Compound 3: middle estimate off by 1.7-fold (0.24 log units), on the low side; the measured number falls inside the stated range.
By their numbers in this assay, from the lowest: compound 2; then compounds 3 and 1 (each within the scatter of the next).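

In this assay, putting (2-amino-1,3-thiazol-4-yl)carbonyl in place of methylsulfonyl on this amine nitrogen in a ring gives a 1.4-fold lower number from compound 1 to compound 3 (0.16 log units; within the scatter), so the two numbers cannot be told apart. This position therefore accepts a group carrying a five-membered aromatic ring, with its hydrogen-bond donor, without a change beyond the scatter.

Still open, going by these compounds, is what a simple acetyl group or a benzoyl group would do on this nitrogen, and how (2-amino-1,3-thiazol-4-yl)carbonyl would act on the core of compound 2. Nothing measured here accounts for the result.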